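Acyl group exchange from compound 1 to compound 4

The source may report more compounds than this note shows. Statements on the series, on what has been measured and on what is new or still open speak of the compounds shown alone.

Measured compounds:
compound 1 `CN(C(=O)NC(=O)c1ccc([N+](=O)[O-])cc1)c1nc(C(F)(F)F)c(C(=O)N/N=C/c2cccc(C(F)(F)F)c2)s1` gives 5.42 ug/mL
compound 2 `CN(C(=O)NC(=O)c1ccc([N+](=O)[O-])cc1)c1nc(C(F)(F)F)c(C(=O)N/N=C/c2ccc([N+](=O)[O-])cc2)s1` gives 8.98 ug/mL
compound 3 `CN(C(=O)NC(=O)c1c(F)cccc1F)c1nc(C(F)(F)F)c(C(=O)N/N=C/c2ccc(C(F)(F)F)cc2)s1` gives 40.1 ug/mL

All numbers come from a functional assay on A549 cells (Homo sapiens) for inhibition, read by MTT assay, with a stated time of 72 h; a lower number here means a stronger inhibitor, a higher number a weaker inhibitor. Compound 1 gives the lowest of the three numbers; compound 2 lies nearest, a 1.7-fold higher number from compound 1 to compound 2 (0.22 log units; within the scatter), and compound 3 lies furthest, beyond the scatter.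

Compound 4 `CN(C(=O)NC(=O)c1ccccc1F)c1nc(C(F)(F)F)c(C(=O)N/N=C/c2cccc(C(F)(F)F)c2)s1` differs from compound 1 in one place: 2-fluorophenyl in place of 4-nitrophenyl on a carbonyl carbon. For the measured compounds named here, no measured step changes only this carbonyl substituent. The step from compound 1 to compound 2 shows that a change at the carbon with a double bond to nitrogen stays within the scatter. Compound 3, which carries a fluorine-substituted phenyl on its carbonyl but also differs at the other ring, gives a clearly higher number than compound 1. Compound 4 is therefore expected to give about 18 ug/mL, between 6 ug/mL and 50 ug/mL. This corresponds to an expected 3.3-fold higher number from compound 1 to compound 4 (0.52 log units; beyond the scatter), toward a weaker inhibitor.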

Compound 4, half-maximal inhibitory concentration: 19.5 ug/mL
Beside the measured number, compound 4's estimate is 1.1-fold (0.03 log units) below it; the range from low to high includes it.
By their numbers in this assay, from the lowest: compounds 1 and 2 (each within the scatter of the next); then compound 4; then compound 3.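

In this assay the change from 4-nitrophenyl to 2-fluorophenyl on a carbonyl carbon gives a 3.6-fold higher number from compound 1 to compound 4 (0.56 log units; beyond the scatter) with nothing else altered. For the compounds shown here, this is the first single-place reading at this carbonyl position, and it shows that the substituent there can move the number beyond the scatter, toward a weaker inhibitor. No evidence on the cause of this step is available.

On these data alone, whether an unsubstituted phenyl or an acetyl group at this carbonyl would give a number closer to compound 1 or to compound 4 remains open. As far as these compounds go, it is also open whether the step keeps its size with 4-nitrophenyl on the carbon with a double bond to nitrogen.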